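Replacing the 4-ethoxyphenyl amide with a carboxy-bearing chain

The compounds below may be only part of what the source reports. "The series", "measured", "known", "first", "only" and "open" are said of these compounds alone.

Of the compounds shown here, three sharing one core have been measured in an assay on cells for agonist activity at vitamin D3 receptor (Homo sapiens), with a stated time of 96 h; a lower number here means that less compound is needed, a higher number that more compound is needed for the effect. Compound 1 `C=CCN(C)C(=O)c1ccc(C(CC)(CC)c2ccc(OCCC(O)(CC)CC)c(C)c2)n1CC` reaches only the limit of the assay, > 10000 nM. Compound 2 `CCn1c(C(=O)Nc2ccc(OC(F)(F)F)cc2)ccc1C(CC)(CC)c1ccc(OCCC(O)(CC)CC)c(C)c1` likewise stops at the limit, > 10000 nM. For the measured compounds named here, compound 3 `CCOc1ccc(NC(=O)c2ccc(C(CC)(CC)c3ccc(OCCC(O)(CC)CC)c(C)c3)n2CC)cc1` is the only one to give a number, 1630 nM. Compound 1 and compound 2 sit at the limit of the assay (the limit of > 10000 nM in this assay, at which 2 of the 3 values shown sit). The step of an at least 6.1-fold lower number from compound 1 to compound 3 (0.78 log units; beyond the scatter) and the step of an at least 6.1-fold lower number from compound 2 to compound 3 (0.78 log units; beyond the scatter) both show that the amide substituent can move the number at least modestly, while a step that the two limits leave unreadable from compound 1 to compound 2 remains unreadable.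

Compound 4 `CCC(C)C(NC(=O)c1ccc(C(CC)(CC)c2ccc(OCCC(O)(CC)CC)c(C)c2)n1CC)C(=O)O` has not been measured. It differs from compound 3 by 1-carboxy-2-methylbutyl in place of 4-ethoxyphenyl on an amide-type nitrogen. Going by the values given here, none of the measured steps exchanges the amide substituent for a chain of this kind, so no direct precedent exists; the measured steps only show that changes at this position can reach at least modest size. Compound 4 is therefore expected to lie near 4000 nM, with a range of 800 nM to 20000 nM, and a real chance that only a limit is reported. This corresponds to an expected 2.5-fold higher number from compound 3 to compound 4 (0.39 log units; beyond the scatter).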

Compound 4, half-maximal effective concentration: 860 nM
Beside the measured number, compound 4's estimate is 4.7-fold (0.67 log units) above it; low and high end bracket the measured number.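

In this assay, the exchange at the amide-type nitrogen gives a 1.9-fold lower number from compound 3 to compound 4 (0.28 log units; within the scatter), so 1-carboxy-2-methylbutyl, which has no ring, cannot be told apart from 4-ethoxyphenyl here. An aromatic ring on this nitrogen is therefore not required for a measurable number, and a ring alone does not secure one, as compound 2 carries a ring and stays at the limit of the assay. Measured from the two compounds held at that limit, the same chain gives an at least 11-fold lower number from compound 2 to compound 4 (1.06 log units; beyond the scatter) and an at least 11-fold lower number from compound 1 to compound 4 (1.06 log units; beyond the scatter), and both steps fix only a minimum size, with the true size unreadable: the limit of > 10000 nM in this assay, at which 2 of the 4 values shown sit.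

The compounds shown leave open whether the carboxylic acid or the branched hydrocarbon part of the chain matters more for the number at this position, as compound 4 carries both together. A methyl ester or a primary amide in place of the carboxylic acid, or a shorter chain such as carboxymethyl, would separate the two contributions.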